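Cyclopropyl on the piperazine nitrogen of compound 3

The source may hold more compounds than are shown below. What is called first, only, known or untested is meant among the compounds shown, and "the series" means these compounds.

Compound 3 `c1ccc2c(c1)CN[C@@H](CN(CCCN1CCNCC1)[C@H]1CCCc3cccnc31)C2` is measured in a functional assay on CCRF-CEM cells for antagonist activity at C-X-C chemokine receptor type 4 (Homo sapiens), read by calcium flux, with stated times of 25 min and 90 s (a higher number here means a weaker inhibitor, a lower number a stronger inhibitor), where compound 3 gives 17 nM. Among the three compounds measured, compound 3 stands second highest. Compound 1 `c1ccc2c(c1)CN[C@@H](CN(CC[C@H]1CCCNC1)[C@H]1CCCc3cccnc31)C2` gives 16 nM, so that a 1.1-fold higher number from compound 1 to compound 3 (0.03 log units; within the scatter). Compound 2 `CCN1CCN(CCCN(C[C@H]2Cc3ccccc3CN2)[C@H]2CCCc3cccnc32)CC1` gives 33 nM, and a 1.9-fold lower number from compound 2 to compound 3 (0.29 log units; within the scatter). Compound 4 `c1ccc2c(c1)CN[C@@H](CN(CCCN1CCN(C3CC3)CC1)[C@H]1CCCc3cccnc31)C2` differs from compound 3 by cyclopropyl in place of hydrogen on an amine nitrogen in a ring.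

Within the data shown here, the one measured step that bears on this change is that between compound 2 and compound 3, where ethyl on the same ring nitrogen was replaced by hydrogen, and it read a 1.9-fold lower number from compound 2 to compound 3 (0.29 log units; within the scatter); read in the other direction, the ethyl group raised the number by a modest amount that stays within the scatter. The step from compound 1 to compound 2 was a 2.1-fold higher number from compound 1 to compound 2 (0.31 log units; beyond the scatter), but it alters two things at once and is less direct a guide.

Cyclopropyl is therefore expected to behave much as ethyl did, and compound 4 is estimated at 26 nM with a range from 11 nM to 65 nM. This estimate means an expected step of a 1.5-fold higher number from compound 3 to compound 4 (0.18 log units; within the scatter), which is not expected to lie beyond the scatter.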

Compound 4, half-maximal inhibitory concentration: 50 nM
Compound 4: middle estimate off by 1.9-fold (0.28 log units), on the low side; low and high end bracket the measured number.
By their numbers in this assay, from the lowest: compounds 1, 3, 2 and 4 (each within the scatter of the next, the first and the last beyond it).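

In this assay, cyclopropyl on the ring nitrogen moves the number beyond the scatter relative to the free piperazine (a 2.9-fold higher number from compound 3 to compound 4 (0.47 log units; beyond the scatter)), which the ethyl group of compound 2 did not do. Cyclopropyl and ethyl at this nitrogen remain indistinguishable (a 1.5-fold higher number from compound 2 to compound 4 (0.18 log units; within the scatter)), so the result does not set the two groups apart. Compound 3 stood within the scatter of compound 1, but the 4-cyclopropylpiperazin-1-yl side chain opens a gap beyond it (a 3.1-fold higher number from compound 1 to compound 4 (0.49 log units; beyond the scatter)).

Nothing shown accounts for the rise at this nitrogen. Going by these compounds, it remains open whether a methyl group, a longer alkyl chain or an acetyl group here would read nearer compound 3 or compound 4, and whether a cyclopropyl group on the piperidine nitrogen of compound 1 would have a similar effect.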